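Replacing Iodo with Methyl on the Shared Core

A few compounds are considered here, and "the series" means these few. Any claim that something is new, unique, unknown or untested is made for them only; others in the source may bear on it.

In an ADME assay on CCRF-CEM cells (Homo sapiens) for antiproliferative activity, with a stated time of 48 h (a higher number here means a weaker inhibitor, a lower number a stronger inhibitor), compound 1 (`C=C(Br)C(=O)Nc1ccc(/C=C/C(=O)c2ccc(Cl)cc2)cc1`) gives 950 nM and compound 2 (`C=C(Br)C(=O)Nc1ccc(/C=C/C(=O)c2ccc(Br)cc2)cc1`) gives 990 nM. Compound 3 (`C=C(Br)C(=O)Nc1ccc(/C=C/C(=O)c2ccc(I)cc2)cc1`) gives 4000 nM, the highest of the three numbers and so the weakest inhibitor of this small set. Compound 4 (`C=C(Br)C(=O)Nc1ccc(/C=C/C(=O)c2ccc(C)cc2)cc1`) has not yet been measured. It departs from compound 3 by one change: methyl in place of iodo on an aromatic carbon. This places methyl in place of iodo on an aromatic carbon, para to a large group.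

For the measured compounds named here, no measured step involves methyl, so the evidence is indirect. Bromo in place of chloro gave a 1.0-fold higher number from compound 1 to compound 2 (0.02 log units; within the scatter), within the scatter. Iodo gave larger, modest steps, a 4.2-fold higher number from compound 1 to compound 3 (0.62 log units; beyond the scatter) and a 4.0-fold higher number from compound 2 to compound 3 (0.61 log units; beyond the scatter). Of the three compounds, only compound 3 stands apart, at 4000 nM, so a modest fall in the number is expected when iodo leaves. The estimated step is a 2.7-fold lower number from compound 3 to compound 4 (0.43 log units; beyond the scatter). For compound 4 the expected value is 1500 nM, with an estimated range of 600 nM to 4000 nM.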

Compound 4, half-maximal inhibitory concentration: 1800 nM
For compound 4 the middle estimate is 1.2-fold (0.08 log units) below the measured one, within the range that was stated.
By their numbers in this assay, from the lowest: compounds 1, 2 and 4 (each within the scatter of the next); then compound 3.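

Compound 4 shows that this carbon does not need a halogen to hold the level of the chloro and bromo compounds. In this assay methyl in place of iodo gives a 2.2-fold lower number from compound 3 to compound 4 (0.35 log units; beyond the scatter) and so recovers part of what iodo gave up, while the step to methyl from bromo is a 1.8-fold higher number from compound 2 to compound 4 (0.26 log units; within the scatter) and the step to methyl from chloro is a 1.9-fold higher number from compound 1 to compound 4 (0.28 log units; within the scatter) and both remain within the scatter. Among these four compounds, then, a change of the group on this carbon separates only compound 3 from the rest, and the 4-methylphenyl compound sits with compounds 1 and 2 rather than forming a new level.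

Whether an amine, a methoxy group or a carboxylic acid on this carbon would stay at that level is left open. Nothing available here gives a reason why iodo alone stands apart.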